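This account rests on a few compounds, and the source may have more. Where it says the series, first, only, none or still open, it means among the compounds named here.

Of the compounds shown here, three have been measured in an ADME assay on microsomes from liver (Mus musculus, strain CD-1) for metabolic stability, read by LC-MS, tested at 2 uM; a higher number here means that the compound lasts longer, a lower number that the compound disappears faster: compound 1 `CNS(=O)(=O)c1ccccc1Nc1cc(-c2ccc3ccn(C)c3c2)c2nccnc2c1`, compound 2 `CN(Cc1cncnc1)S(=O)(=O)c1ccccc1Nc1cc(-c2ccc3ccn(C)c3c2)c2nccnc2c1` and compound 3 `Cn1cc(NC(=O)c2ccncc2Nc2cc(-c3ccc4ccn(C)c4c3)c3nccnc3c2)cn1`. In this assay compound 1 gives 0.2 h, compound 2 gives 0.2 h and compound 3 gives 0.2 h, so compound 3 stands level with both. For the measured compounds named here, the one measured step, no change at the digits printed from compound 1 to compound 2 (within the scatter), stayed within the scatter. Compound 4 `CC(=O)N1CCOC(CNC(=O)c2ccncc2Nc2cc(-c3ccc4ccn(C)c4c3)c3nccnc3c2)C1` differs from compound 3 in this way: (4-acetylmorpholin-2-yl)methyl in place of 1-methyl-1H-pyrazol-4-yl on an amide-type nitrogen. Going by the values given here, no measured step touches an amide nitrogen, and the only change measured anywhere left this assay flat, so the change is expected to leave the half-life where it is, which for compound 4 means no change at the digits printed from compound 3 to compound 4 (within the scatter). The estimate for compound 4 is 0.2 h, within the range 0.1 h to 0.5 h.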

Compound 4, half-life: 0.217 h
Compound 4: middle estimate off by 1.1-fold (0.04 log units), on the low side; the measured number falls inside the stated range.
By their numbers in this assay, from the lowest: compounds 1, 2, 3 and 4 (each within the scatter of the next).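

Placing (4-acetylmorpholin-2-yl)methyl in place of 1-methyl-1H-pyrazol-4-yl on the amide-type nitrogen gives a 1.1-fold higher number from compound 3 to compound 4 (0.04 log units; within the scatter) in this assay. This position therefore tolerates a swap from a five-membered aromatic ring to a six-membered non-aromatic ring, with 10 heavy atoms entering for 6, without a step beyond the scatter. No measurement bears on why the half-life stays the same here. On these data alone, whether a basic amine or a carboxylic acid on this nitrogen would give a different half-life stays open. So does whether any change to the shared core would.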